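From 2-chlorophenyl to 4-hydroxyphenyl on the shared core

The source may hold more compounds than are shown below. What is called first, only, known or untested is meant among the compounds shown, and "the series" means these compounds.

Of the compounds shown here, three with a shared core have been measured in a functional assay on PANC-1 cells (Homo sapiens) for inhibition, read by MTT assay, with a stated time of 24 h; a higher number here means a weaker inhibitor, a lower number a stronger inhibitor. Compound 1 `CC1(C)[C@H]2CC[C@]1(C)N(Cc1cn(-c3cccc(F)c3)nn1)C(=O)C2` gives 220 nM, compound 2 `CC1(C)[C@H]2CC[C@]1(C)N(Cc1cn(-c3ccccc3C#N)nn1)C(=O)C2` gives 240 nM, and compound 3 `CC1(C)[C@H]2CC[C@]1(C)N(Cc1cn(-c3ccccc3Cl)nn1)C(=O)C2` gives 270 nM. The steps among them are a 1.1-fold higher number from compound 1 to compound 2 (0.04 log units; within the scatter), a 1.2-fold higher number from compound 1 to compound 3 (0.09 log units; within the scatter) and a 1.1-fold higher number from compound 2 to compound 3 (0.05 log units; within the scatter), all within the scatter. Compound 3 therefore stands level with the other two, and this assay does not separate the three.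

The next compound, compound 4 `CC1(C)[C@H]2CC[C@]1(C)N(Cc1cn(-c3ccc(O)cc3)nn1)C(=O)C2`, differs from compound 3 in the group on the aromatic nitrogen: 4-hydroxyphenyl in place of 2-chlorophenyl on an aromatic nitrogen. All three measured steps bear on this change, as each exchanges one substituted phenyl group for another at that same place. Going by the values given here, none of them, however, involves a 4-hydroxyphenyl group, so the data offer no direct precedent and the range must stay wide. Compound 3, at 270 nM, is the starting point, and the exchange of groups in a 1.1-fold higher number from compound 2 to compound 3 (0.05 log units; within the scatter) is the closest guide to size. On that basis, no step beyond the scatter is expected, and no direction can be favoured with confidence. The expected step is a 1.1-fold higher number from compound 3 to compound 4 (0.05 log units; within the scatter). For compound 4 the estimated value is 300 nM, with an expected range of 110 nM to 800 nM.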

Compound 4, half-maximal inhibitory concentration: 100 nM
Beside the measured number, compound 4's estimate is 3.0-fold (0.48 log units) above it; the whole stated range lies above it.
By their numbers in this assay, from the lowest: compound 4; then compounds 1, 2 and 3 (each within the scatter of the next).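

In this assay, the group on the aromatic nitrogen now separates the compounds: the earlier exchanges among substituted phenyl groups stayed within the scatter, whereas 4-hydroxyphenyl gives a 2.7-fold lower number from compound 3 to compound 4 (0.43 log units; beyond the scatter), a 2.4-fold lower number from compound 2 to compound 4 (0.38 log units; beyond the scatter) and a 2.2-fold lower number from compound 1 to compound 4 (0.34 log units; beyond the scatter), each modest but beyond the scatter. Going by these compounds alone, this makes compound 4 the strongest inhibitor of the four, and it is also the only one whose group on that nitrogen counts a hydrogen-bond donor and a hydrogen-bond acceptor, though this is an observation from a single compound and not an explanation. Nothing measured here accounts for the lower number.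

Compound 4 differs from the others in both the substituent and its place on the phenyl ring, so the compounds shown do not tell whether the hydroxy group, its place or the two together go with the change. Going by these compounds, how a 3-hydroxyphenyl, 4-methoxyphenyl or 4-aminophenyl group would read at this position also remains open, and these would test how far the result depends on the hydroxy group itself.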